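Swapping an acetyl for a thiophene carbonyl on an anilide chalcone

This account rests on a few compounds, and the source may have more. Where it says the series, first, only, none or still open, it means among the compounds named here.

Measured so far:
- compound 1, `O=C(/C=C/c1ccc([N+](=O)[O-])cc1)c1ccc(O)c(O)c1`: 5800 nM
- compound 2, `O=C(/C=C/c1ccccc1)c1ccc(NC(=O)c2cccs2)cc1`: 12000 nM
- compound 3, `CC(=O)Nc1ccc(C(=O)/C=C/c2cccc([N+](=O)[O-])c2)cc1`: 1700 nM

All three were tested in a functional assay on HCT-116 cells (Homo sapiens) for cytotoxicity, read by resazurin assay, with a stated time of 48 h; on this read-out lower numbers stand for an effect already at smaller amounts and higher numbers for an effect only at larger amounts of compound. Among the three, compound 3 gives the lowest number; compound 1 comes nearest, and compound 2 stands furthest away, both gaps being beyond the usual scatter. Compound 4, `O=C(/C=C/c1cccc([N+](=O)[O-])c1)c1ccc(NC(=O)c2cccs2)cc1`, has not yet been measured. It differs from compound 3 in one place, (thiophen-2-yl in place of methyl on a carbonyl carbon), so that the acetamido group becomes a ((thiophen-2-yl)carbonyl)amino group. Going by the values given here, no two measured compounds differ by exactly this change, so its size cannot be read off directly. Compound 2 carries the same ((thiophen-2-yl)carbonyl)amino group and gives 12000 nM, but it lacks the nitro group of compound 3, so the two compounds differ in more than one place and its value only sets a loose reference. The step is expected to be modest, in the direction of a higher number, a 1.9-fold higher number from compound 3 to compound 4 (0.27 log units; within the scatter). Compound 4 is therefore estimated at 3200 nM, within 1000 nM to 10000 nM.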

Compound 4, half-maximal effective concentration: 2600 nM
For compound 4 the middle estimate is 1.2-fold (0.09 log units) above the measured one; the range from low to high includes it.
By their numbers in this assay, from the lowest: compounds 3 and 4 (each within the scatter of the next); then compound 1; then compound 2.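

Replacing methyl with thiophen-2-yl on a carbonyl carbon gives a 1.5-fold higher number from compound 3 to compound 4 (0.18 log units; within the scatter) and so leaves the two compounds indistinguishable, even though a five-membered aromatic ring takes the place of a single carbon. With the ((thiophen-2-yl)carbonyl)amino group held constant, nitro in place of hydrogen on an aromatic carbon gives a 4.6-fold lower number from compound 2 to compound 4 (0.66 log units; beyond the scatter) and provides the first readable measure of what the nitro group adds, a step that lies beyond the scatter. Nothing measured here explains the size of either step.

From the compounds shown here alone, only methyl and thiophen-2-yl are compared on this carbonyl carbon, so it remains open how a phenyl ring, a longer chain or a group carrying an amine would read there. Going by these compounds, it also remains open whether nitro in place of hydrogen would give a similar step in a compound with the acetamido group.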